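A few compounds are considered here, and "the series" means these few. Any claim that something is new, unique, unknown or untested is made for them only; others in the source may bear on it.

The set comprises two pairs built on different cores. Compound 1 `COc1ccc(Cc2nnc3n2NC(c2ccc[nH]2)S3)cc1OC` and compound 3 `COc1ccc(Cc2nnc3n2NC(c2cccn2C)S3)cc1OC` share one core, while compound 2 `Cc1occc1-c1nnc2n1NC(c1ccc[nH]1)S2` and the as yet unmeasured compound 4 `Cc1occc1-c1nnc2n1NC(c1cccn1C)S2` share another; the difference between the two cores is not broken down here. Within the first pair, compound 3 differs from compound 1 by methyl in place of hydrogen on an aromatic nitrogen. Within the second pair, compound 4 differs from compound 2 by methyl in place of hydrogen on an aromatic nitrogen, the same change at the same place.

In a functional assay on the whole organism (strain Wistar Albino) for inhibition, with Rattus norvegicus as the target, read by paw edema, with a stated time of 3 h, at a dose of 20 mg/kg (a lower number here means less inhibition, a higher number more inhibition at the dose given (going by the name of the read-out)), compound 1 gives 17.7%. Compound 3 gives 18.4% in this assay, so the step of a number 0.7 percentage points higher from compound 1 to compound 3 (within the scatter) lies within the scatter of repeated measurements. Compound 2 gives 20.3% in this assay; its value and those of compound 1 and compound 3 all lie within the scatter of one another, so none of the three can be set apart from the others.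

Among the measured compounds shown here, the only guide to compound 4 is the measured pair on the first core. Because a number 0.7 percentage points higher from compound 1 to compound 3 (within the scatter) did not move the read-out beyond the scatter, the same change on compound 2 is expected to leave its value about where it stands. For compound 4 the expected step is a number 0.7 percentage points higher from compound 2 to compound 4 (within the scatter), set beside the measured a number 0.7 percentage points higher from compound 1 to compound 3 (within the scatter). Compound 4 is thus expected to give 21% in this assay, with a plausible range from 12% to 30%. Whether that holds awaits the measurement.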

Compound 4, a percentage reported as inhibition, in the whole organism at one dose (the size of the read-out at that dose, not a potency): 21.5%
Compound 4: middle estimate off by 0.5 percentage points, on the low side; low and high end bracket the measured number.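

In this assay, the change from 1H-pyrrol-2-yl to 1-methyl-1H-pyrrol-2-yl gives a number 1.2 percentage points higher from compound 2 to compound 4 (within the scatter), and set beside the earlier step on the other core, the same change reads alike on both cores: the same change on two cores in this assay, a number 0.7 percentage points higher (within the scatter) from compound 1 to compound 3 and a number 1.2 percentage points higher (within the scatter) from compound 2 to compound 4, 0.5 percentage points apart, within the scatter of two such steps. This shows that, on these two cores, putting methyl in place of hydrogen on the aromatic nitrogen leaves the paw edema read-out within the scatter, so the result on the first core carried over to the second as a lack of any clear effect. It does not show that the methyl has a real effect of any size or direction, and two pairs read at a single dose cannot show that the change would behave in the same way on any other core, or that a step beyond the scatter would carry over between them.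

The compounds shown carry only hydrogen or methyl on that aromatic nitrogen, which leaves open what a longer chain such as propyl, or a benzyl group, would do at the same place. Also open, on these data alone, is how the same change would read on a core carrying an amine or a carboxylic acid.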